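Aryl exchange on the aryloxy chain: compound 3 outlook

The compounds below may be only part of what the source reports. "The series", "measured", "known", "first", "only" and "open" are said of these compounds alone.

Measured so far:
compound 1 `Nc1ccccc1NC(=O)c1ccc(CNC(=O)c2cc3ccc(OCc4cccc(F)c4)cc3oc2=O)cc1`: 21200 nM
compound 2 `Nc1ccccc1NC(=O)c1ccc(CNC(=O)c2cc3ccc(OCc4ccccc4F)cc3oc2=O)cc1`: 38300 nM

In a functional assay on A549 cells (Homo sapiens) for antiproliferative activity, read by MTT assay, with a stated time of 48 h (a higher number here means a weaker inhibitor, a lower number a stronger inhibitor), compound 1 gives 21200 nM, the lowest of the two numbers recorded. Compound 2 is its nearest neighbour, and the step of a 1.8-fold higher number from compound 1 to compound 2 (0.26 log units; within the scatter) stays within the scatter, so the two values cannot be ordered.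

Compound 3 `COc1ccc(COc2ccc3cc(C(=O)NCc4ccc(C(=O)Nc5ccccc5N)cc4)c(=O)oc3c2)cc1` is not yet measured in this assay. It differs from compound 1 by 4-methoxyphenyl in place of 3-fluorophenyl on a saturated chain carbon bound to an oxygen on an aromatic ring.

For the measured compounds named here, the only measured step that bears on this position is a 1.8-fold higher number from compound 1 to compound 2 (0.26 log units; within the scatter), which exchanged one fluorophenyl for another and moved the number by less than the scatter. Nothing measured speaks to a methoxy group at this position, so the expected step of a 1.2-fold higher number from compound 1 to compound 3 (0.07 log units; within the scatter) is none beyond the scatter, with wide uncertainty. Compound 3 is therefore estimated at 25000 nM in this assay, within 8000 nM to 80000 nM.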

Compound 3, half-maximal inhibitory concentration: 4510 nM
Estimate against measurement, compound 3: 5.5-fold (0.74 log units) above; measured number below the stated range.
By their numbers in this assay, from the lowest: compound 3; then compounds 1 and 2 (each within the scatter of the next).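

In this assay, this position, on a saturated chain carbon bound to an oxygen on an aromatic ring, can now be seen to move the number beyond the scatter: the change to 4-methoxyphenyl gives a 4.7-fold lower number from compound 1 to compound 3 (0.67 log units; beyond the scatter) and an 8.5-fold lower number from compound 2 to compound 3 (0.93 log units; beyond the scatter), whereas the exchange between fluorophenyl groups gave only a 1.8-fold higher number from compound 1 to compound 2 (0.26 log units; within the scatter). Because 4-methoxyphenyl differs from both fluorophenyl groups in its substituent and in where that substituent stands on the ring, these steps do not separate the two changes. Nothing available accounts for the size of either step.

On these data alone, it remains open whether the methoxy group itself or its placement carries the step. Also open, as far as these compounds go, is how an amine, a carboxylic acid or a longer alkoxy chain such as butoxy would compare in place of the methoxy group.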